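Changing the Acyl Group of Compound 1 at Its Carbonyl

The source may hold more compounds than are shown below. What is called first, only, known or untested is meant among the compounds shown, and "the series" means these compounds.

Compound 1 `CCCCC(=O)NC(=S)Nc1nc2cc([N+](=O)[O-])ccc2s1` gives > 100000 nM in a functional assay on MCF7 cells (Homo sapiens) for cytotoxicity, read by MTT assay, with a stated time of 24 h (on this read-out higher numbers stand for weaker inhibition and lower numbers for stronger inhibition), and this is a limit of the assay rather than a number (the limit of > 100000 nM in this assay, at which 1 of the 3 values shown sits). For the measured compounds named here, it therefore stands at the weak end of the three values measured so far. Compound 2 `CCCCC(=O)NC(=S)Nc1nc2cc(Br)ccc2s1` gives 45700 nM in this assay, and compound 3 `CCCCC(=O)NC(=S)Nc1nc2cc(N)ccc2s1` gives 44700 nM. Both steps away from compound 1 change the group on an aromatic carbon of the shared core: an at least 2.1-fold lower number from compound 1 to compound 2 (0.34 log units; beyond the scatter) and an at least 2.2-fold lower number from compound 1 to compound 3 (0.34 log units; beyond the scatter). Between compound 2 and compound 3, a 1.0-fold lower number from compound 2 to compound 3 (0.01 log units; within the scatter).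

Compound 4 `O=C(NC(=S)Nc1nc2cc([N+](=O)[O-])ccc2s1)c1ccc([N+](=O)[O-])cc1` differs from compound 1 elsewhere: 4-nitrophenyl in place of butyl on a carbonyl carbon. Going by the values given here, none of the measured steps touches the carbonyl carbon; all three keep the butyl group and vary only the substituent on the aromatic carbon. They thus give no direct guidance on the size or direction of the step to compound 4, and the nitro group on the aromatic carbon, which compound 1 shares with compound 4, is the one that goes with the weakest value seen. Compound 4 is expected to remain near that weak end, with a number no higher from compound 1 to compound 4 (the limit leaves the size open) expected to stay within the scatter. The estimate for compound 4 in this assay is 100000 nM, with a range from 30000 nM to 300000 nM.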

Compound 4, half-maximal inhibitory concentration: 35200 nM
The estimate for compound 4 lay 2.8-fold (0.45 log units) above the measured number; measured number inside the range.
By their numbers in this assay, from the lowest: compounds 4, 3 and 2 (each within the scatter of the next). At a limit, above all of these: compound 1.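

Compound 4 is the first compound shown in which the group on the carbonyl carbon changes, and in this assay 4-nitrophenyl in place of butyl gives an at least 2.8-fold lower number from compound 1 to compound 4 (0.45 log units; beyond the scatter). The nitro group on the aromatic carbon of the shared core stays in place across this step, so the carbonyl carbon is a second place where a single change moves the number beyond the scatter, as the changes on the aromatic carbon had done. How large the step really is stays open, because compound 1 stands at a limit and not at a number: the limit of > 100000 nM in this assay, at which 1 of the 4 values shown sits.

Going by these compounds, what a plain phenyl or a longer alkyl chain such as octyl would give on the carbonyl carbon remains open, so it cannot be told whether the lower number goes with the six-membered ring itself or with the nitro group it carries. It is also unknown whether 4-nitrophenyl on the carbonyl carbon would have the same effect with bromo or amino on the aromatic carbon, since compound 2 and compound 3 both keep butyl.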